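The compounds below may be only part of what the source reports. "The series", "measured", "known", "first", "only" and "open" are said of these compounds alone.

Compound 1 `OCCCCC#Cc1ccccc1C#Cc1ccccn1`: 26100 nM in a functional assay on OVCAR-3 cells (Homo sapiens) for cytotoxicity; a lower number here means a stronger inhibitor of growth, a higher number a weaker inhibitor of growth.
Compound 2 `OCCCCC#Cc1ccccc1C#Cc1ccc(O)cc1`: 14800 nM in this assay.

Going by the values given here, compound 2 is one of only two compounds measured in this assay. Among the compounds with values here, its sole neighbour is compound 1, and the step of a 1.8-fold lower number from compound 1 to compound 2 (0.25 log units; within the scatter) is within the scatter, so the two numbers cannot be told apart. Compound 3 `N#Cc1ccc(C#Cc2ccccc2C#CCCCCO)cc1` has not been measured. It differs from compound 2 by cyano in place of hydroxy on an aromatic carbon, the cyano sitting on an aromatic carbon of a six-membered aromatic ring of carbon only, para to a large group. Within the data shown here, no measured step touches this substituent: the only measured step exchanged the whole ring on the triple-bonded carbon and stayed within the scatter. On that basis no step beyond the scatter is expected in this assay from this exchange, in either direction. The step of a 1.0-fold higher number from compound 2 to compound 3 (0.01 log units; within the scatter) is expected to stay within the scatter. Compound 3 is therefore estimated at 15000 nM, in the range 5000 nM to 45000 nM.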

Compound 3, concentration for 50% growth inhibition: 19900 nM
Estimate against measurement, compound 3: 1.3-fold (0.12 log units) below; the range from low to high includes it.
By their numbers in this assay, from the lowest: compounds 2, 3 and 1 (each within the scatter of the next).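

Going by these compounds alone, replacing hydroxy with cyano on this aromatic carbon, para to a large group, gives a 1.3-fold higher number from compound 2 to compound 3 (0.13 log units; within the scatter) in this assay and is the only measured change that touches this substituent directly. The hydrogen-bond donor of hydroxy is absent from cyano, yet the numbers of the two compounds cannot be told apart, so this position has so far shown no measurable response to the exchange. No available evidence accounts for this outcome.

Going by these compounds, with only hydroxy and cyano compared here, it remains open whether an amine or a carboxylic acid on the same aromatic carbon would move the number beyond the scatter. Also open, on these data alone, is whether a longer chain in place of the hydroxy-bearing chain of the shared core would do so.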